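Methyl for hydrogen on the stilbene-like core of compound 1

The compounds below may be only part of what the source reports. "The series", "measured", "known", "first", "only" and "open" are said of these compounds alone.

Compound 1 `COc1ccc(C(N)=O)cc1/C=C/c1ccccc1` carries an unsubstituted phenyl ring on its core. Among the measured compounds shown here, in an ADME assay on HCT-116 cells (Homo sapiens) for antiproliferative activity (on this read-out lower numbers stand for stronger inhibition and higher numbers for weaker inhibition), compound 1 gives 36000 nM, the highest of the two numbers known so far. Its nearest neighbour is compound 2 `COc1ccc(C(N)=O)cc1/C=C/c1cccc(C#N)c1`, which in this assay gives 19000 nM; the step of a 1.9-fold lower number from compound 1 to compound 2 (0.28 log units; within the scatter) is within the scatter. The change to compound 3 `COc1ccc(C(N)=O)cc1/C=C/c1ccccc1C` is methyl in place of hydrogen on an aromatic carbon. For the measured compounds named here, no measured step bears on this change directly: the one known step concerns a cyano group rather than a methyl, and it stayed within the scatter. Compound 3 is therefore expected to sit close to compound 1, with an estimated step of a 1.2-fold lower number from compound 1 to compound 3 (0.08 log units; within the scatter) that does not go beyond the scatter. For compound 3 an estimated value of 30000 nM is expected, within a range from 12000 nM to 75000 nM.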

Compound 3, half-maximal inhibitory concentration: 11000 nM
For compound 3 the middle estimate is 2.7-fold (0.44 log units) above the measured one; measured number outside the range, below it.
By their numbers in this assay, from the lowest: compounds 3, 2 and 1 (each within the scatter of the next, the first and the last beyond it).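

In this assay, methyl in place of hydrogen on an aromatic carbon, ortho to a large group, gives a 3.3-fold lower number from compound 1 to compound 3 (0.51 log units; beyond the scatter) as a modest but real change. Among the steps shown, this is the only one beyond the scatter, whereas cyano in place of hydrogen gives a 1.9-fold lower number from compound 1 to compound 2 (0.28 log units; within the scatter) and stays within it. So this ring of the core of compound 1 can respond to a single added carbon, though no measurement shown accounts for the step.

The compounds shown leave open whether methyl on a different carbon of this ring would give a step of similar size. They also leave open whether a longer chain such as ethyl, or an amine, in the place ortho to a large group would carry the change further or lose it.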